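Sulfonyl substituent size in a Bcl-2/Bak binding series

The source may report more compounds than this note shows. Statements on the series, on what has been measured and on what is new or still open speak of the compounds shown alone.

Measured compounds in an assay on isolated protein for inhibition of Apoptosis regulator Bcl-2/Bcl-2 homologous antagonist/killer (Homo sapiens), read by surface plasmon resonance, with a stated time of 1 h; on this read-out lower numbers stand for an effect already at smaller amounts and higher numbers for an effect only at larger amounts of compound:
compound 1 `CCS(=O)(=O)NC(=O)c1ccc(N2CCN(Cc3ccccc3-c3ccc(Cl)cc3)CC2)cc1`, 5310 nM
compound 2 `CC1(C)[C@@]2(C)CC[C@H](CS(=O)(=O)NC(=O)c3ccc(N4CCN(Cc5ccccc5-c5ccc(Cl)cc5)CC4)cc3)[C@]1(C)C2`, 560 nM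
compound 3 `CC1(C)[C@]2(C)CC[C@@H](CS(=O)(=O)NC(=O)c3ccc(N4CCN(Cc5ccccc5-c5ccc(Cl)cc5)CC4)cc3)[C@@]1(C)C2`, 420 nM

Compound 3 gives the lowest number of the three, though its separation from compound 2 is within the scatter, since a 1.3-fold lower number from compound 2 to compound 3 (0.12 log units; within the scatter) and the two differ only in configuration (the fact that compounds 2 and 3 differ only in the configuration as drawn). Against compound 1 the separation is clear: a 13-fold lower number from compound 1 to compound 3 (1.10 log units; beyond the scatter), and likewise a 9.5-fold lower number from compound 1 to compound 2 (0.98 log units; beyond the scatter).

Compound 4 `CC(C)(C)S(=O)(=O)NC(=O)c1ccc(N2CCN(Cc3ccccc3-c3ccc(Cl)cc3)CC2)cc1` is not yet measured. Its change from compound 3 is a group of 4 heavy atoms (4 carbon; no ring) in place of a group of 12 heavy atoms (12 carbon; one four-membered non-aromatic ring of carbon only, one six-membered non-aromatic ring of carbon only), on a sulfonyl sulfur: the tert-butyl group enters where the bicyclic group stood, on the sulfonyl sulfur next to the amide-type nitrogen.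

Among the compounds with values here, the steps that bear on this are those from compound 1 to the bicyclic analogues, in which a group of 11 heavy atoms replaced one carbon atom and gave a modest to large lowering. Compound 4 carries a group of 4 heavy atoms with no ring, between the two extremes measured so far. A higher number than compound 3 is therefore expected, but short of compound 1; the expected step is a 4.8-fold higher number from compound 3 to compound 4 (0.68 log units; beyond the scatter). The estimated value for compound 4 is 2000 nM, in the range 700 nM to 6000 nM.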

Compound 4, half-maximal effective concentration: > 16000 nM
Compound 4 gave a limit, no number (the forecaster's own chance of this, stated with the estimate: 3%); middle value at least 8.0-fold (0.90 log units) away from the limit.
By their numbers in this assay, from the lowest: compounds 3 and 2 (each within the scatter of the next); then compound 1. At a limit, above all of these: compound 4.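

In this assay compound 4 gives > 16000 nM, which is a limit of the assay and not a number. The steps to it can still be read as minimum sizes, and they show that the low numbers of the two mirror-image compounds are not kept once tert-butyl replaces their larger group on the sulfonyl sulfur: an at least 38-fold higher number from compound 3 to compound 4 (1.58 log units; beyond the scatter) and an at least 28-fold higher number from compound 2 to compound 4 (1.45 log units; beyond the scatter). New to the series is that adding carbon at this position does not by itself lower the number, since tert-butyl in place of ethyl gives an at least 3.0-fold higher number from compound 1 to compound 4 (0.47 log units; beyond the scatter), the opposite direction to a 13-fold lower number from compound 1 to compound 3 (1.10 log units; beyond the scatter), so heavy atom count alone does not order compounds 1, 3 and 4.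

Compounds 2 and 3 place a chain carbon on the sulfonyl sulfur and compound 1 does too, whereas compound 4 has its fully substituted carbon there, so the shown set cannot separate the loss of the ring groups from that change of attachment. As far as these compounds go, a neopentyl or a cyclohexylmethyl group on the sulfonyl sulfur would bear on that question, and how far compound 4 lies past its limit stays unknown.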